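This account rests on a few compounds, and the source may have more. Where it says the series, first, only, none or still open, it means among the compounds named here.

Among the compounds with values here, in a functional assay on DU-145 cells (Homo sapiens) for inhibition, read by trypan blue exclusion, with a stated time of 96 h (a higher number here means a weaker inhibitor of growth, a lower number a stronger inhibitor of growth), compound 1 `O=C(/C(=C\c1ccc(Br)c(O)c1)S(=O)(=O)c1ccc(Br)cc1)c1ccc(Br)cc1` reads 50000 nM and compound 2 `O=C(/C(=C\c1ccc(F)cc1F)S(=O)(=O)c1ccc(Cl)cc1)c1ccc(Br)cc1` reads 25000 nM as the only numbers so far. These two values lie within the usual scatter of repeated measurements, so compound 2 stands level with compound 1 and neither can be ranked over the other. Both are single readings, and they give only a rough sense of where this family sits.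

The next compound is compound 3 `O=C(/C(=C\c1ccc(F)cc1F)S(=O)(=O)c1ccc(Br)cc1)c1ccc(Br)cc1`, which differs from compound 2 in one place. The change bromo in place of chloro on an aromatic carbon puts bromo in place of chloro on an aromatic carbon, para to a large group, so that 4-chlorophenyl becomes 4-bromophenyl. Everything else in the structure stays the same. Within the data shown here, no measured pair here shows what this swap does, so there is no direct precedent, and nothing in the data points up or down. The expected step of no change at the digits printed from compound 2 to compound 3 (within the scatter) is therefore none beyond the scatter in this assay for now. Compound 3 is estimated at 25000 nM with an expected range from 10000 nM to 60000 nM on this read-out.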

Compound 3, concentration for 50% growth inhibition: 7500 nM
Estimate against measurement, compound 3: 3.3-fold (0.52 log units) above; measured number below the stated range.
By their numbers in this assay, from the lowest: compound 3; then compounds 2 and 1 (each within the scatter of the next).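

In this assay, replacing chloro with bromo on an aromatic carbon, para to a large group, gives a 3.3-fold lower number from compound 2 to compound 3 (0.52 log units; beyond the scatter) and takes the number beyond the scatter. Within the data shown here, this position therefore responds to an exchange of one halogen for another, even though only one heavy atom changes and the count of hydrogen-bond donors and acceptors stays the same. The other group matters as well: 2,4-difluorophenyl in place of 4-bromo-3-hydroxyphenyl gives a 6.7-fold lower number from compound 1 to compound 3 (0.82 log units; beyond the scatter) and leaves compound 3 with the lowest number of the three, although no measurement shown here gives a reason for either step.

As far as these compounds go, the halogen result rests on a single pair, so it remains open whether the same exchange would give a step of similar size with a different group on the double-bonded chain carbon. From the compounds shown here alone, it is also open how 4-iodophenyl, 4-methoxyphenyl, or a phenyl ring carrying an amine would read at this position, and so whether the trend extends beyond chloro and bromo.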